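Extending the Side Chain Trend to Compound 3

A few compounds are considered here, and "the series" means these few. Any claim that something is new, unique, unknown or untested is made for them only; others in the source may bear on it.

Measured in a functional assay on MIA PaCa-2 cells (Homo sapiens) for antiproliferative activity, read by MTT assay, with a stated time of 3 days; on this read-out lower numbers stand for stronger inhibition and higher numbers for weaker inhibition:
Compound 1 `CCCCCc1ccc(C#Cc2cn(C/C=C/CN3C(=O)c4ccccc4C3=O)c(=O)[nH]c2=O)cc1`: 26000 nM
Compound 2 `CCCCc1ccc(C#Cc2cn(C/C=C/CN3C(=O)c4ccccc4C3=O)c(=O)[nH]c2=O)cc1`: 79000 nM

Compound 2 gives the higher of the two numbers, at 79000 nM. Compound 3 `O=C1c2ccccc2C(=O)N1C/C=C/Cn1cc(C#CCCc2ccccc2)c(=O)[nH]c1=O` has phenethyl in place of 4-butylphenyl on a triple-bonded carbon. Within the data shown here, one measured step bears on this only loosely, since it places hydrogen in place of methyl on a saturated chain carbon, and it is a 3.0-fold higher number from compound 1 to compound 2 (0.48 log units; beyond the scatter). A modest step toward a higher number in this assay is therefore expected, with a real chance that the assay reports only a limit. The expected step is a 1.5-fold higher number from compound 2 to compound 3 (0.18 log units; within the scatter). For compound 3 the estimated value is 120000 nM, within a range of 50000 nM to 300000 nM.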

Compound 3, half-maximal inhibitory concentration: 27000 nM
Compound 3: the middle estimate sits 4.4-fold (0.65 log units) above what was measured, outside the stated range (below it).
By their numbers in this assay, from the lowest: compounds 1 and 3 (each within the scatter of the next); then compound 2.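

In this assay, phenethyl in place of 4-butylphenyl on the triple-bonded carbon gives a 2.9-fold lower number from compound 2 to compound 3 (0.47 log units; beyond the scatter), so a change at this position can lower the number without a longer chain on the phenyl ring. Phenethyl in place of 4-pentylphenyl gives a 1.0-fold higher number from compound 1 to compound 3 (0.02 log units; within the scatter), within the scatter, so these two groups cannot be told apart in this read-out. No available evidence accounts for either step. Still open, from the compounds shown here alone, is how a longer chain between the triple-bonded carbon and the phenyl ring would read, and whether an amine on that chain would change the number.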